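A few compounds are considered here, and "the series" means these few. Any claim that something is new, unique, unknown or untested is made for them only; others in the source may bear on it.

Measured in an ADME assay on MT4 cells (Homo sapiens) for cytotoxicity, read by MTT assay, with a stated time of 5 days; on this read-out lower numbers stand for higher toxicity in this test and higher numbers for lower toxicity in this test
- compound 1 (`Cc1cc(C)cc(S(=O)(=O)c2c(C(N)=O)[nH]c3ccc(Cl)cc23)c1`) gives 13000 nM
- compound 2 (`Cc1cc(C)cc(S(=O)(=O)c2c(C(=O)NC3CN(Cc4n[nH]c(=O)n4C)C3)[nH]c3ccc(Cl)cc23)c1`) gives 25200 nM
- compound 3 (`CCS(=O)(=O)NC(=O)c1[nH]c2ccc(Cl)cc2c1S(=O)(=O)c1cc(C)cc(C)c1`) gives > 283000 nM as a limit, not a number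

Compound 3 therefore stands at the top of the range shown, with the limit of > 283000 nM in this assay, at which 1 of the 3 values shown sits, as its only reading. Two large steps lead to it: an at least 21-fold higher number from compound 1 to compound 3 (1.33 log units; beyond the scatter) and an at least 11-fold higher number from compound 2 to compound 3 (1.05 log units; beyond the scatter). The remaining step, a 1.9-fold higher number from compound 1 to compound 2 (0.29 log units; within the scatter), lies within the scatter.

Compound 4 (`Cc1cc(C)cc(S(=O)(=O)c2c(C(=O)NS(=O)(=O)C3CC3)[nH]c3ccc(Cl)cc23)c1`) carries one change, (cyclopropyl in place of ethyl on a sulfonyl sulfur), that is, cyclopropyl in place of ethyl on a sulfonyl sulfur. Within the data shown here, no measured step alters this group, so the two large steps bear on it only indirectly: compound 4 keeps the sulfonyl on the amide-type nitrogen. No step beyond the scatter is therefore expected in this assay, and another limit is quite likely. The expected step is an at least 1.2-fold lower number from compound 3 to compound 4 (0.10 log units; that floor lies within the scatter) and it stays an estimate. For compound 4 the estimated value is 220000 nM, with an expected range of 70000 nM to 300000 nM.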

Compound 4, half-maximal cytotoxic concentration: 147000 nM
For compound 4 the middle estimate is 1.5-fold (0.18 log units) above the measured one, and the stated range covers the measured number.
By their numbers in this assay, from the lowest: compounds 1 and 2 (each within the scatter of the next); then compound 4. At a limit, above all of these: compound 3.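

In this assay, cyclopropyl in place of ethyl on the sulfonyl sulfur gives an at least 1.9-fold lower number from compound 3 to compound 4 (0.28 log units; that floor lies within the scatter), so the size of this change remains unsettled. The gain seen with ethylsulfonyl also holds with cyclopropylsulfonyl on the amide-type nitrogen, now as a measured number: an 11-fold higher number from compound 1 to compound 4 (1.05 log units; beyond the scatter), and a 5.8-fold higher number from compound 2 to compound 4 (0.77 log units; beyond the scatter). Compound 3 remains a limit, not a number: the limit of > 283000 nM in this assay, at which 1 of the 4 values shown sits.

From the compounds shown here alone, whether a phenyl group, a longer chain such as butyl, or an amine on the sulfonyl sulfur would keep the number this far up stays open.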